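Methoxy for Nitro on the Thiazolylidene Hydrazide Series

The compounds below may be only part of what the source reports. "The series", "measured", "known", "first", "only" and "open" are said of these compounds alone.

Cytotoxicity here is read in a functional assay on C6 cells (Rattus norvegicus) for cytotoxicity, read by MTT assay, with a stated time of 24 h; on this read-out higher numbers stand for weaker inhibition and lower numbers for stronger inhibition. Compound 1, `Cn1nnnc1SCC(=O)N/N=c1/scc(-c2ccccc2)n1-c1ccccc1`, gives 67.7 ug/mL. Compound 2, `O=C(CSc1ncccn1)N/N=c1/scc(-c2ccc(Br)cc2)n1-c1ccccc1`, reaches only a limit of the assay, > 200 ug/mL. Compound 3, `Cc1nnc(SCC(=O)N/N=c2/scc(-c3ccc([N+](=O)[O-])cc3)n2-c2ccccc2)s1`, is recorded in this assay as "not determined" (no result reported), so it stands without a number; among the three values shown, one sits at the limit of > 200 ug/mL in this assay, at which 1 of the 3 values shown sits. Compound 4, `COc1ccc(-c2cs/c(=N/NC(=O)CSc3nnc(C)s3)n2-c2ccccc2)cc1`, differs from compound 3 by methoxy in place of nitro on an aromatic carbon. Among the measured compounds shown here, with no measured step between these two compounds, the size and direction of the change cannot be read from the data; the expectation is for a step no larger than the scatter, in either direction. Compound 4 is therefore estimated to give 120 ug/mL, within a range of 40 ug/mL to 200 ug/mL.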

Compound 4, half-maximal inhibitory concentration: 18.7 ug/mL
Beside the measured number, compound 4's estimate is 6.4-fold (0.81 log units) above it; the measured number lies below the stated range.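

Among the compounds shown here, compound 3 carries no number, so no step from it to compound 4 can be read. Whether methoxy in place of nitro shifts cytotoxicity stays open, and nothing shown accounts for the value of compound 4.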